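A few compounds are considered here, and "the series" means these few. Any claim that something is new, unique, unknown or untested is made for them only; others in the source may bear on it.

Measured in an ADME assay on L02 cells (Homo sapiens) for cytotoxicity, read by MTT assay, with a stated time of 48 h; a lower number here means a stronger inhibitor, a higher number a weaker inhibitor:
- compound 1 `C#CCNC(=O)c1ccc(C(CC)(CC)c2ccc(OCC(O)C(C)(C)C)c(C)c2)n1CC`: 4400 nM
- compound 2 `CCn1c(C(=O)NCCN)ccc1C(CC)(CC)c1ccc(OCC(O)C(C)(C)C)c(C)c1`: 2400 nM
- compound 3 `C#CC(C)OC(=O)c1ccc(C(CC)(CC)c2ccc(OCC(O)C(C)(C)C)c(C)c2)n1CC`: 23700 nM

Of the three, compound 3 has the highest number, 23700 nM. Compound 4 `CCn1c(C(=O)N(C)CC(=O)O)ccc1C(CC)(CC)c1ccc(OCC(O)C(C)(C)C)c(C)c1` has (carboxymethyl)(methyl)amino in place of (1-methylprop-2-yn-1-yl)oxy on a carbonyl carbon. Among the compounds with values here, two measured steps bear on this change, a 5.4-fold higher number from compound 1 to compound 3 (0.73 log units; beyond the scatter) and a 9.9-fold higher number from compound 2 to compound 3 (0.99 log units; beyond the scatter). Both are modest, and both put (1-methylprop-2-yn-1-yl)oxy where an amino group stood, so the reverse exchange should lower the number. Within the data shown here, no measured compound carries the carboxymethyl group, which leaves the size uncertain. In this assay a modest drop is expected, estimated as a 2.2-fold lower number from compound 3 to compound 4 (0.33 log units; beyond the scatter). The estimate for compound 4 is 11000 nM, with an expected range of 3500 nM to 40000 nM.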

Compound 4, half-maximal inhibitory concentration: 32600 nM
Compound 4: the middle estimate sits 3.0-fold (0.47 log units) below what was measured; measured number inside the range.
By their numbers in this assay, from the lowest: compounds 2 and 1 (each within the scatter of the next); then compounds 3 and 4 (each within the scatter of the next).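

In this assay, an amino group on the carbonyl carbon does not by itself keep the number low: (carboxymethyl)(methyl)amino gives a 14-fold higher number from compound 2 to compound 4 (1.13 log units; beyond the scatter) and a 7.4-fold higher number from compound 1 to compound 4 (0.87 log units; beyond the scatter). Against (1-methylprop-2-yn-1-yl)oxy, the same group gives a 1.4-fold higher number from compound 3 to compound 4 (0.14 log units; within the scatter), so the earlier link between an amino group and a lower number holds only for propargylamino and (2-aminoethyl)amino.

Nothing measured here accounts for this. The compounds shown leave open whether the carboxylic acid or the methyl on the nitrogen separates compound 4 from compounds 1 and 2, which a (carboxymethyl)amino group or a methyl ester could test.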